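The source may report more compounds than this note shows. Statements on the series, on what has been measured and on what is new or still open speak of the compounds shown alone.

Working notes on the series. In a functional assay on HCT-116 cells (Homo sapiens) for antiproliferative activity, read by WST assay, with a stated time of 72 h (a lower number here means a stronger inhibitor of growth, a higher number a weaker inhibitor of growth), compound 1 (`N#Cc1ccc(CN[C@H]2[C@@H]3CN(c4ncc(C(=O)NO)cn4)C[C@@H]32)cc1`) gives 270 nM. Compound 2 (`O=C(NO)c1cnc(N2C[C@@H]3[C@H](C2)[C@H]3NC(=O)c2ccc3ccccc3c2)nc1`) gives 410 nM, and compound 3 (`O=C(NO)c1cnc(N2C[C@@H]3[C@H](C2)[C@H]3NCC2CCCCC2)nc1`) gives 160 nM. The value of compound 1 lies within the scatter of both of the other two values, so it has no clear rank among them.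

Compound 4 (`O=C(NO)c1cnc(N2C[C@@H]3[C@H](C2)[C@H]3NCc2ccc(C(F)(F)F)cc2)nc1`) has not yet been measured in this assay. Its change from compound 1 is trifluoromethyl in place of cyano on an aromatic carbon of a six-membered aromatic ring of carbon only, para to a large group (trifluoromethyl in place of cyano on an aromatic carbon).

Among the compounds with values here, no measured step isolates this substituent. The closest evidence is a 1.7-fold lower number from compound 1 to compound 3 (0.23 log units; within the scatter), where cyclohexyl replaces the whole 4-cyanophenyl group on a saturated chain carbon bound to an amine nitrogen. Compound 2 differs from compound 1 in more than one place and offers no clean comparison. Within the data shown here, with only that one step to draw on, and with it inside the scatter, no shift beyond the scatter is expected for the smaller exchange of cyano for trifluoromethyl, and no direction can be assigned with confidence.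

The expected step is a 1.1-fold lower number from compound 1 to compound 4 (0.05 log units; within the scatter), which is an estimate within the scatter. For compound 4 the estimated value is 240 nM, with an expected range of 100 nM to 560 nM.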

Compound 4, concentration for 50% growth inhibition: 700 nM
The estimate for compound 4 lay 2.9-fold (0.46 log units) below the measured number; the whole stated range lies below it.
By their numbers in this assay, from the lowest: compounds 3, 1, 2 and 4 (each within the scatter of the next, the first and the last beyond it).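

In this assay, within the data shown here, trifluoromethyl in place of cyano on an aromatic carbon, para to a large group, gives a 2.6-fold higher number from compound 1 to compound 4 (0.41 log units; beyond the scatter); this is the only step so far that lies beyond the scatter. The substituent at this place on the six-membered aromatic ring therefore matters to the read-out, even though the larger exchange of the whole 4-cyanophenyl group for cyclohexyl, a 1.7-fold lower number from compound 1 to compound 3 (0.23 log units; within the scatter), stays within the scatter, so the size of an exchange does not track the size of the step in these two pairs. No measurement at hand bears on the reason for the shift.

Still open, from the compounds shown here alone, is whether the step reflects the loss of the nitrile or the entry of the trifluoromethyl group, a question that a bare hydrogen, a chlorine, a methoxy group or a primary amide at the same place could help to settle. Also open, going by these compounds, is whether the same exchange gives a step of similar size at other places on the ring, or with the amide link of compound 2 in place of the amine.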